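Adding a 2-hydroxyethyl chain to compound 1

The compounds below may be only part of what the source reports. "The series", "measured", "known", "first", "only" and "open" are said of these compounds alone.

In a functional assay on HeLa cells (Homo sapiens) for antiproliferative activity, read by sulforhodamine B assay (on this read-out higher numbers stand for weaker inhibition of growth and lower numbers for stronger inhibition of growth), compound 1 (`O[C@H]1CO[C@H](COCc2ccccc2)[C@@H](OCc2ccccc2)[C@@H]1OCc1ccccc1`) gives > 50000 nM, which is a limit of the assay and not a number. That makes it (the limit of > 50000 nM in this assay, at which 1 of the 3 values shown sits). Compound 4 (`OCC[C@@H]1O[C@H](COCc2ccccc2)[C@@H](OCc2ccccc2)[C@H](OCc2ccccc2)[C@H]1O`) is related to compound 1 by one change: 2-hydroxyethyl in place of hydrogen on a saturated ring carbon. This places 2-hydroxyethyl in place of hydrogen on a saturated ring carbon, next to the ring oxygen.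

The closest guide is compound 3 (`CC(C)C[C@H]1O[C@H](COCc2ccccc2)[C@@H](OCc2ccccc2)[C@H](OCc2ccccc2)[C@H]1O`), which gives 43900 nM in this assay. Here isobutyl replaces hydrogen, and the measured step is an at least 1.1-fold lower number from compound 1 to compound 3 (0.05 log units; that floor lies within the scatter). Compound 2 (`CCC[C@H]1O[C@H](COCc2ccc(F)cc2)[C@@H](OCc2ccc(F)cc2)[C@H](OCc2ccc(F)cc2)[C@H]1O`) gives 5600 nM, but it differs from compound 1 in more than one place, so it offers no clean comparison.

Since compound 3 shows only an at least 1.1-fold lower number from compound 1 to compound 3 (0.05 log units; that floor lies within the scatter), a modest move toward stronger inhibition of growth is the most that can be expected. The expected step is an at least 2.0-fold lower number from compound 1 to compound 4 (0.30 log units; that floor lies within the scatter). For compound 4 the estimated value is 25000 nM, with an expected range of 8000 nM to 50000 nM.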

Compound 4, concentration for 50% growth inhibition: 30200 nM
Beside the measured number, compound 4's estimate is 1.2-fold (0.08 log units) below it, within the range that was stated.
By their numbers in this assay, from the lowest: compound 2; then compounds 4 and 3 (each within the scatter of the next). At a limit, above all of these: compound 1.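

In this assay, compound 1 gives > 50000 nM, which is a limit of the assay and not a number. From the compounds shown here alone, the step to the 2-hydroxyethyl chain is therefore only a floor, an at least 1.6-fold lower number from compound 1 to compound 4 (0.21 log units; that floor lies within the scatter), and its true size stays unknown because compound 1 sits at that limit: the limit of > 50000 nM in this assay, at which 1 of the 4 values shown sits. On this ring carbon next to the ring oxygen, the two chains now give values within the scatter of each other, with compound 4 at 30200 nM and compound 3 at 43900 nM, so these two compounds do not tell 2-hydroxyethyl and isobutyl apart.

Going by these compounds, whether an amine, a carboxylic acid or a longer chain on this carbon would give a clearly different number remains open. Compound 2 gives 5600 nM, but it differs from the others in more than one place, so that value cannot be traced to any single change.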